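The compounds below may be only part of what the source reports. "The series", "measured", "known", "first", "only" and "open" are said of these compounds alone.

Measured so far:
compound 1, `CC(C)(CC(=O)N[C@@H]1CCc2ccccc2N(Cc2ccc(-c3ccccc3-c3nn[nH]n3)cc2)C1=O)NCCO` — 30 uM
compound 2, `CC(C)CNC(C)(C)CC(=O)N[C@@H]1CCc2ccccc2N(Cc2ccc(-c3ccccc3-c3nn[nH]n3)cc2)C1=O` — 85 uM
compound 3, `CC(C)(N)C(=O)N[C@@H]1CCc2ccccc2N(Cc2ccc(-c3ccccc3-c3nn[nH]n3)cc2)C1=O` — 0.03 uM

In a functional assay on cells (Pituitary gland cell) with growth hormone secretagogue receptor type 1 (Rattus norvegicus) as the target (on this read-out higher numbers stand for an effect only at larger amounts of compound and lower numbers for an effect already at smaller amounts), compound 3 holds the lowest number of the three by a wide margin: a 1000-fold lower number from compound 1 to compound 3 (3.00 log units; beyond the scatter) and a 2800-fold lower number from compound 2 to compound 3 (3.45 log units; beyond the scatter), both well beyond the scatter. The two compounds with the extended chain on the carbonyl carbon sit close to each other, the gap between them being only modest (a 2.8-fold higher number from compound 1 to compound 2 (0.45 log units; beyond the scatter)).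

Compound 4, `CCCNC(C)(C)CC(=O)N[C@@H]1CCc2ccccc2N(Cc2ccc(-c3ccccc3-c3nn[nH]n3)cc2)C1=O`, is not yet measured. It differs from compound 3 by 2-methyl-2-(propylamino)propyl in place of 1-amino-1-methylethyl on a carbonyl carbon. The relevant comparisons are the two steps from the chain-extended compounds to compound 3, since compound 4 reverses that change: a propylamino replaces the hydroxyethylamino of compound 1 and the isobutylamino of compound 2, and the change from compound 1 to compound 2 altered the number only modestly. Both comparison steps were large, so a large rise in the read-out of this assay is expected from compound 3 to compound 4, landing near the numbers of compound 1 and compound 2.

Compound 4 is estimated at 50 uM, with an expected range of 15 uM to 150 uM. The expected step is a 1700-fold higher number from compound 3 to compound 4 (3.22 log units; beyond the scatter).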

Compound 4, concentration for half-maximal effect: 50 uM
Beside the measured number, compound 4's estimate shows no gap at the digits printed; the measured number falls inside the stated range.
By their numbers in this assay, from the lowest: compound 3; then compounds 1, 4 and 2 (each within the scatter of the next, the first and the last beyond it).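

In this assay the 2-methyl-2-(propylamino)propyl group on the carbonyl carbon gives a 1700-fold higher number from compound 3 to compound 4 (3.22 log units; beyond the scatter) and so places compound 4 with the other two extended chains, a third amine substituent on that chain leaving the number far from that of compound 3. The propyl end adds no separation within this group: a 1.7-fold lower number from compound 2 to compound 4 (0.23 log units; within the scatter) and a 1.7-fold higher number from compound 1 to compound 4 (0.22 log units; within the scatter) are both within the scatter, although compound 1 and compound 2 themselves differ beyond it, so at this level the chain length and the amine substituent tested here do little to distinguish these three compounds. No measurement is available that accounts for the large step at this position.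

The step from compound 3 to compound 4 joins a longer chain on the carbonyl carbon with a propyl group on the amine nitrogen, and the compounds shown do not tell which of the two carries the large rise. A 2-amino-2-methylpropyl group, with a free primary amine on the longer chain, and a 1-methyl-1-(propylamino)ethyl group, with the propylamine on the short chain, would each separate these two parts of the change.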